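This account rests on a few compounds, and the source may have more. Where it says the series, first, only, none or still open, it means among the compounds named here.

Of the compounds shown here, three have numbers so far, all in a functional assay on RAW264.7 cells (Mus musculus) for inhibition, read by Griess assay, with stated times of 2 h and 24 h; a lower number here means a stronger inhibitor, a higher number a weaker inhibitor. Compound 1 `CCCCn1cc(COc2cc(O)c3c(c2)O[C@H](c2ccc(OC)c(O)c2)C/C3=N\O)nn1` gives 8900 nM. Compound 2 `CCCn1cc(COc2cc(O)c3c(c2)O[C@H](c2ccc(OC)c(O)c2)C/C3=N\O)nn1` gives 2340 nM. Compound 3 `COc1ccc([C@@H]2C/C(=N\O)c3c(O)cc(OCc4cn(C5CCCC5)nn4)cc3O2)cc1O` gives 6880 nM, the second highest number of the three: the step of a 1.3-fold lower number from compound 1 to compound 3 (0.11 log units; within the scatter) stays within the scatter, while the step of a 2.9-fold higher number from compound 2 to compound 3 (0.47 log units; beyond the scatter) lies beyond it. Among the chains, the step of a 3.8-fold lower number from compound 1 to compound 2 (0.58 log units; beyond the scatter) is modest.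

Compound 4 `COc1ccc([C@@H]2C/C(=N\O)c3c(O)cc(OCc4cn(-c5ccccc5)nn4)cc3O2)cc1O` differs from compound 3 in one place: phenyl in place of cyclopentyl on an aromatic nitrogen. Going by the values given here, the measured steps that touch the same aromatic nitrogen, a 1.3-fold lower number from compound 1 to compound 3 (0.11 log units; within the scatter) and a 2.9-fold higher number from compound 2 to compound 3 (0.47 log units; beyond the scatter), exchange a chain for the cyclopentyl and reach at most a modest size; no measured step exchanges a saturated ring for an aromatic one, so the direction of this change is not probed by the data. The expectation is therefore a step of at most modest size in this assay, direction open, a 1.1-fold lower number from compound 3 to compound 4 (0.06 log units; within the scatter). Compound 4 is estimated at 6000 nM, with a range of 2000 nM to 20000 nM.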

Compound 4, half-maximal inhibitory concentration: 6130 nM
For compound 4 the middle estimate is 1.0-fold (0.01 log units) below the measured one; the measured number falls inside the stated range.
By their numbers in this assay, from the lowest: compound 2; then compounds 4, 3 and 1 (each within the scatter of the next).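

In this assay, going by these compounds alone, the exchange of a saturated ring for an aromatic one on this aromatic nitrogen, read here for the first time (a 1.1-fold lower number from compound 3 to compound 4 (0.05 log units; within the scatter)), stays within the scatter. Phenyl also stays within the scatter of butyl (a 1.5-fold lower number from compound 1 to compound 4 (0.16 log units; within the scatter)), but not of propyl (a 2.6-fold higher number from compound 2 to compound 4 (0.42 log units; beyond the scatter)), so compounds 1, 3 and 4 do not separate, and of the four groups at this position only the propyl of compound 2 stands apart. No measurement on hand offers an explanation for this reading.

Going by these compounds, it remains open whether the propyl result is an isolated point or whether an ethyl or methyl group would give a still lower number. Also open, on these data alone, is how a benzyl group, a methoxy-bearing phenyl or a chain ending in an amine would read at this position.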